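Aryl exchange in a series sitting at the assay limit

The compounds below may be only part of what the source reports. "The series", "measured", "known", "first", "only" and "open" are said of these compounds alone.

Among the measured compounds shown here, compound 1 (`Cc1ccc(S(=O)(=O)N[C@@H](CC(=O)NC(C)(C)C)C(=O)NCCNC(=O)c2ccc(F)cc2)cc1`) and compound 2 (`Cc1ccc(S(=O)(=O)N[C@@H](CC(=O)NC(C)(C)C)C(=O)NCCNC(=O)c2cc(C)ccc2F)cc1`) are the two measured members in an ADME assay on Karpas-1106P cells (Homo sapiens) for cytotoxicity; on this read-out higher numbers stand for an effect only at larger amounts of compound and lower numbers for an effect already at smaller amounts. Compound 1 gives > 11100 nM, which is a limit and not a number. Compound 2 gives > 11100 nM, which is likewise a limit. Compound 2 therefore has no number of its own and stands at the limit of > 11100 nM in this assay, at which 2 of the 2 values shown sit.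

Compound 3 (`C#Cc1cccc(C(=O)NCCNC(=O)[C@H](CC(=O)NC(C)(C)C)NS(=O)(=O)c2ccc(C)cc2)c1`) carries 3-ethynylphenyl in place of 2-fluoro-5-methylphenyl on a carbonyl carbon.

For the measured compounds named here, one measured step bears on this change, as it also exchanges the group on that carbonyl carbon: a step that the two limits leave unreadable from compound 1 to compound 2. With limits at both ends, it supplies no size and no direction. It does show that the exchange of 2-fluoro-5-methylphenyl for 4-fluorophenyl left both values as limits in this assay. On that basis, no step beyond the scatter is expected, and no direction is favoured. The estimated step is a step that the limit leaves unreadable from compound 2 to compound 3. Compound 3 is expected to come in at 12000 nM, with an estimated range from 5000 nM to 30000 nM.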

Compound 3, half-maximal effective concentration: > 11100 nM
Compound 3 gave a limit, no number (the forecaster's own chance of this, stated with the estimate: 80%); the middle value lies beyond the limit too.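

No step can be read among compound 1, compound 2 and compound 3 in this assay, as each value is a limit and not a number: the limit of > 11100 nM in this assay, at which 3 of the 3 values shown sit.

The compounds shown leave open whether exchanging the group on the carbonyl carbon changes this read-out at all, and where each compound's actual value lies.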